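The source may report more compounds than this note shows. Statements on the series, on what has been measured and on what is new or still open speak of the compounds shown alone.

Compound 1 `C/C(=C\C(=O)Nc1ccccc1OCCCC(=O)O)c1ccc2c(ccn2C)c1`: 780 nM
Compound 2 `CCCCC(C)n1ccc2cc(/C(C)=C/C(=O)Nc3ccccc3OCCCC(=O)O)ccc21`: 6 nM

Of these two, compound 2 gives the lower number in an assay on Prostate gland for inhibition of steroid 5-alpha-reductase (Rattus norvegicus); a lower number here means a stronger inhibitor, a higher number a weaker inhibitor. Compound 3 `CCCCC(CCCC)n1ccc2cc(/C(C)=C/C(=O)Nc3ccccc3OCCCC(=O)O)ccc21` carries propyl in place of hydrogen on a saturated chain carbon, two bonds along the chain from an aromatic nitrogen. Among the measured compounds shown here, one measured step bears on this change: a 130-fold lower number from compound 1 to compound 2 (2.11 log units; beyond the scatter), a large gain from enlarging the substituent on the aromatic nitrogen. Compound 3 enlarges that substituent further, so a smaller shift in the same direction, or none beyond the scatter, is expected. For compound 3 the expected step is a 1.5-fold lower number from compound 2 to compound 3 (0.18 log units; within the scatter). Compound 3 is therefore estimated at 4 nM, within 1.5 nM to 12 nM.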

Compound 3, half-maximal inhibitory concentration: 21 nM
Compound 3: middle estimate off by 5.3-fold (0.72 log units), on the low side; the whole stated range lies below it.
By their numbers in this assay, from the lowest: compound 2; then compound 3; then compound 1.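

In this assay the gain from enlarging the substituent on the aromatic nitrogen does not continue without limit: propyl in place of hydrogen on the saturated chain carbon gives a 3.5-fold higher number from compound 2 to compound 3 (0.54 log units; beyond the scatter), so 1-butylpentyl falls short of 1-methylpentyl. Much of the gain over methyl remains, with a 37-fold lower number from compound 1 to compound 3 (1.57 log units; beyond the scatter) still large. No measurement shown here accounts for this reversal. From the compounds shown here alone, whether a pentyl chain without a branch or a cyclohexyl group on the aromatic nitrogen would match 1-methylpentyl stays open.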